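The source may report more compounds than this note shows. Statements on the series, on what has been measured and on what is new or still open speak of the compounds shown alone.

Measured compounds:
- compound 1, `C/C(=N\NC(=O)COc1cccc2ccccc12)c1ccc(C#N)cc1Br`: 12.7 ug/mL
- compound 2, `COc1cc(/C=N/NC(=O)COc2cccc3ccccc23)cc(OC)c1OC`: 47.9 ug/mL
- compound 3, `O=C(COc1cccc2ccccc12)N/N=C/c1ccc(O)cc1`: 60.6 ug/mL

All three share the same core and were tested in an ADME assay on HEL cells (Homo sapiens) for cytotoxicity; a higher number here means that more compound is tolerated, a lower number that less compound is tolerated. In this assay compound 3 gives 60.6 ug/mL, the highest of the three numbers, although its gap to compound 2 at 47.9 ug/mL lies within the usual scatter of this kind of measurement. Only compound 1, at 12.7 ug/mL, sits clearly apart, beyond the scatter, on the side of less tolerated compound.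

Compound 4, `O=C(COc1cccc2ccccc12)N/N=C/c1ccccc1Br`, has not yet been measured. It differs from compound 3 in one place:

2-bromophenyl in place of 4-hydroxyphenyl on a carbon with a double bond to nitrogen

Going by the values given here, no step between measured compounds shows what this change does on its own. Among the compounds with values here, compound 1, the one measured compound that carries a bromine on its aromatic ring, gives the lowest number, which suggests a lower number for compound 4 as well. The step from compound 3 is therefore expected to be a moderate one downward, a 2.4-fold lower number from compound 3 to compound 4 (0.38 log units; beyond the scatter), beyond the scatter but not large. Compound 4 is estimated to give about 25 ug/mL in this assay, with a likely range from 10 ug/mL to 55 ug/mL.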

Compound 4, half-maximal cytotoxic concentration: 100 ug/mL
Beside the measured number, compound 4's estimate is 4.0-fold (0.60 log units) below it; the whole stated range lies below it.
By their numbers in this assay, from the lowest: compound 1; then compounds 2, 3 and 4 (each within the scatter of the next, the first and the last beyond it).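

In this assay, putting 2-bromophenyl in place of 4-hydroxyphenyl on a carbon with a double bond to nitrogen gives a 1.7-fold higher number from compound 3 to compound 4 (0.22 log units; within the scatter) and so leaves the number within the scatter. At this position, then, the hydrogen-bond donor and acceptor counted on 4-hydroxyphenyl can leave and a bromine can enter without a clear shift, so a bromine on this ring does not by itself bring a clearly lower number. No measurement at hand explains this outcome.

As far as these compounds go, compound 1 differs from compound 4 in more than one place, so which of its features goes with its lower number stays open. Also open, from the compounds shown here alone, is how this position would respond to a phenyl ring carrying an amine or a carboxylic acid.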